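Hydroxy in Place of Amino on a Selenium Nucleoside

This account rests on a few compounds, and the source may have more. Where it says the series, first, only, none or still open, it means among the compounds named here.

Compound 1 `OC[C@H]1O[C@@H](n2cnc3c(O)ncnc32)C[Se]1` gives > 100000 nM in a functional assay on CCRF-CEM cells (Homo sapiens) for cytotoxicity; on this read-out higher numbers stand for weaker inhibition and lower numbers for stronger inhibition.
Compound 2 `Nc1ncnc2c1ncn2[C@@H]1C[Se][C@@H](CO)O1` gives > 100000 nM in this assay.

Both values are limits of the assay, not numbers. Compound 2 therefore stands at the limit, as does compound 1. Compound 3 `OC[C@H]1O[C@H](n2cnc3c(O)ncnc32)C[Se]1` differs from compound 2 by hydroxy in place of amino on an aromatic carbon. For the measured compounds named here, no measured pair isolates this change. Because the limit of > 100000 nM in this assay, at which 2 of the 2 values shown sit, holds every value shown, compound 3 is expected to remain at or near that limit, with no step beyond the scatter. The step that the limit leaves unreadable from compound 2 to compound 3 is thus expected to be small. Compound 3 is estimated at 150000 nM, between 50000 nM and 500000 nM.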

Compound 3, half-maximal inhibitory concentration: > 100000 nM
Compound 3: only a limit was reported; the forecaster's own chance of this, stated with the estimate: 85%; the middle value is on the limit's open side.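

In this assay compound 3 gives > 100000 nM, a limit and not a number, so the steps to compound 3 from compound 1 and compound 2 cannot be read. From the compounds shown here alone, whether hydroxy in place of amino, or the configuration at the saturated ring carbon, changes anything in this assay remains open.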